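The compounds below may be only part of what the source reports. "The series", "measured", "known", "first", "only" and "open" are said of these compounds alone.

Measured in a functional assay on the whole organism (strain albino) with Mus musculus as the target, in the maximal electroshock model, with a stated time of 0.5 h; a lower number here means that less compound is needed, a higher number that more compound is needed for the effect:
- Compound 1 `O=C1c2ccccc2C(=O)N1c1cccc(Cl)c1`: 190 mg/kg
- Compound 2 `O=C1c2ccccc2C(=O)N1c1cccc([N+](=O)[O-])c1`: 174 mg/kg

The two measured compounds lie within the scatter of each other, and compound 2 stands at 174 mg/kg. Compound 3 `COc1cccc(N2C(=O)c3ccccc3C2=O)c1` keeps the core of compound 2 and carries methoxy in place of nitro on an aromatic carbon, meta to a large group (methoxy in place of nitro on an aromatic carbon). For the measured compounds named here, one measured step bears on this change: a 1.1-fold lower number from compound 1 to compound 2 (0.04 log units; within the scatter), where nitro took the place of chloro on an aromatic carbon. Going by the values given here, no measured compound carries methoxy, so this evidence is indirect. Even so, the one exchange seen so far moved the number by no more than the scatter, and no larger shift is expected in this assay. The expected result is a 1.0-fold lower number from compound 2 to compound 3 (0.01 log units; within the scatter), with no direction beyond the scatter. For compound 3 the estimated value is 170 mg/kg, with an expected range of 85 mg/kg to 340 mg/kg.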

Compound 3, dose for half-maximal effect: > 300 mg/kg
Compound 3 gave a limit, no number; the forecaster's own chance of this, stated with the estimate: 15%; middle value at least 1.7-fold (0.24 log units) from the limit.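

In this assay compound 3 gives > 300 mg/kg, a limit and not a number, and it is the only compound shown that ends at one: the limit of > 300 mg/kg in this assay, at which 1 of the 3 values shown sits. With methoxy on this aromatic carbon, the steps read an at least 1.7-fold higher number from compound 2 to compound 3 (0.23 log units; that floor lies within the scatter) and an at least 1.5-fold higher number from compound 1 to compound 3 (0.19 log units; that floor lies within the scatter). Both are floors only, so the exchange at this position, which had stayed within the scatter from chloro to nitro, now has a result with no upper bound on its size.

As far as these compounds go, how far compound 3 truly lies from compound 1 and compound 2 remains open, as does whether the gap exceeds the scatter at all. Also open, from the compounds shown here alone, is how an amine or a longer chain on this same aromatic carbon would read in this assay.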